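This account rests on a few compounds, and the source may have more. Where it says the series, first, only, none or still open, it means among the compounds named here.

Two compounds measured in a functional assay (muscle tissue) with Cavia porcellus as the target (on this read-out lower numbers stand for an effect already at smaller amounts and higher numbers for an effect only at larger amounts of compound), form the background here. Compound 1, `COC(=O)C1=C(C)N=C(C)/C(=C(\O)OC)C1c1cccc(O)c1`, gives 1000 nM. Compound 2, `COC(=O)C1=C(C)N=C(C)/C(=C(\O)OC)C1c1ccccc1I`, gives 46.8 nM. For the measured compounds named here, the one step between them is a 21-fold lower number from compound 1 to compound 2 (1.33 log units; beyond the scatter), brought about by a 2-iodophenyl in place of a 3-hydroxyphenyl on a saturated ring carbon. On these two numbers compound 2 stands lowest, with compound 1 the nearest neighbour and far above it.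

Compound 3, `COC(=O)C1=C(C)N=C(C)/C(=C(\O)OC)C1c1ccccc1C#N`, is the next compound, differing from compound 2 in one spot: cyano in place of iodo on an aromatic carbon

Going by the values given here, no measured step swaps the iodo group alone, so the only guide is the step from compound 1 to compound 2, which changed both the group and where it sits on the ring; it shows that this part of the molecule can move this assay a great deal, but it does not tell which way a cyano group will pull. Bearing that uncertainty in mind, compound 3 is expected to show a 3.2-fold higher number from compound 2 to compound 3 (0.51 log units; beyond the scatter), a modest rise that may still sit near the scatter. The estimate for compound 3 in this assay is therefore 150 nM, with a range from 30 nM to 750 nM.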

Compound 3, half-maximal effective concentration: 15.9 nM
Compound 3: the middle estimate sits 9.4-fold (0.97 log units) above what was measured, and the stated range ends above it.
By their numbers in this assay, from the lowest: compound 3; then compound 2; then compound 1.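

With the spot held fixed, a 2.9-fold lower number from compound 2 to compound 3 (0.47 log units; beyond the scatter) in this assay, so the identity of the group on this aromatic carbon, ortho to a large group, matters in its own right and not only its location on the ring. The lower number also shows that the single iodine atom is not needed for a low value here, as a cyano group with its triple bond and hydrogen-bond acceptor serves at least as well in this comparison, while a 63-fold lower number from compound 1 to compound 3 (1.80 log units; beyond the scatter) widens the distance from the 3-hydroxyphenyl compound, though that step changes both the group and its place. Nothing measured here explains why cyano gives the lower number of the two.

The compounds shown include no pair carrying the same group in two different places, so how much of the distance from compound 1 belongs to the group and how much to its location stays open. Also open, as far as these compounds go, is how other groups on this aromatic carbon, such as an amine, a carboxylic acid or a longer chain, would behave in this assay.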